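The source may hold more compounds than are shown below. What is called first, only, known or untested is meant among the compounds shown, and "the series" means these compounds.

In a functional assay on RAW264.7 cells (Mus musculus) for inhibition, with stated times of 2 h and 24 h (a higher number here means a weaker inhibitor, a lower number a stronger inhibitor), compound 1, `COc1ccc([C@@H]2c3c(OC)cc(OC)cc3C(O)[C@H]2c2cc(OC)cc(OC)c2)cc1`, gives 7870 nM. Compound 2, `COc1ccc(C(O)C2c3cc(OC)cc(OC)c3[C@@H](c3ccc(OC)cc3)[C@@H]2c2cc(OC)cc(OC)c2)cc1`, reports only a limit, > 200000 nM. Compound 3, `COc1ccc([C@@H]2c3c(OC)cc(OC)cc3C(C(O)c3ccccc3)[C@H]2c2cc(OC)cc(OC)c2)cc1`, also reports only a limit, > 200000 nM, and so stands at the limit of > 200000 nM in this assay, at which 2 of the 3 values shown sit.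

Compound 4, `COc1ccc([C@@H]2c3c(OC)cc(OC)cc3C(C(O)c3ccc(C)cc3)[C@H]2c2cc(OC)cc(OC)c2)cc1`, differs from compound 3 by methyl in place of hydrogen on an aromatic carbon, para to a large group, which turns hydroxy(phenyl)methyl into hydroxy(4-methylphenyl)methyl.

Two measured steps set the background. Hydroxy(4-methoxyphenyl)methyl in place of hydroxy gave an at least 25-fold higher number from compound 1 to compound 2 (1.40 log units; beyond the scatter), and hydroxy(phenyl)methyl in place of hydroxy gave an at least 25-fold higher number from compound 1 to compound 3 (1.40 log units; beyond the scatter). The closest measured change on the aromatic ring itself is hydrogen in place of methoxy, a step that the two limits leave unreadable from compound 2 to compound 3, so it gives no size to carry over.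

With both substituted analogues at the limit, a return toward compound 1 seems unlikely, and no change beyond the scatter is expected in this assay, though another limit is likely. The expected step is a number no higher from compound 3 to compound 4 (the limit leaves the size open). For compound 4 the estimated value is 200000 nM, with an expected range from 60000 nM to 400000 nM.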

Compound 4, half-maximal inhibitory concentration: 26500 nM
For compound 4 the middle estimate is 7.5-fold (0.88 log units) above the measured one, and the stated range ends above it.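

In this assay, methyl in place of hydrogen on the aromatic ring, para to a large group, gives an at least 7.5-fold lower number from compound 3 to compound 4 (0.87 log units; beyond the scatter), and methyl in place of methoxy at that place gives an at least 7.5-fold lower number from compound 2 to compound 4 (0.87 log units; beyond the scatter). Among these compounds, the earlier compounds showed only that the larger side groups ended at a limit, whereas compound 4 shows that this side group can carry a readable value and that the ring substituent decides this, although hydroxy(4-methylphenyl)methyl in place of hydroxy still gives a 3.4-fold higher number from compound 1 to compound 4 (0.53 log units; beyond the scatter). Both steps from the limits are bounds, not exact sizes: the limit of > 200000 nM in this assay, at which 2 of the 4 values shown sit.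

The compounds shown leave open whether this gain is particular to methyl or also extends to ethyl, chlorine or an amine at the same place. They also leave open whether any such group would close the remaining gap to compound 1.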